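Methoxy on the aryl ring of a furan amide

This account rests on a few compounds, and the source may have more. Where it says the series, first, only, none or still open, it means among the compounds named here.

Measured compounds in an assay on CHO cells for displacement of a labelled ligand from adenosine receptor A1 (Homo sapiens), read by scintillation counting, with a stated time of 120 min, tested at 1 uM; on this read-out higher numbers stand for more inhibition at the one concentration tested (going by the name of the read-out) and lower numbers for less inhibition:
Compound 1 `COc1ccc(-n2cc3nc(C)nc(NC(=O)Nc4ccccc4)c3n2)cc1` gives 5%.
Compound 2 `COc1ccc(-n2cc3nc(C)nc(NC(=O)NCc4ccccc4)c3n2)cc1` gives 8%.
Compound 3 `Cc1nc(NC(=O)c2ccco2)c2nn(-c3ccccc3)cc2n1` gives 20%.

Of the three numbers in this assay, the value of compound 3 is the highest, and its gaps to compound 2 and compound 1 lie beyond the usual scatter of repeated measurements. Compound 4 `COc1ccc(-n2cc3nc(C)nc(NC(=O)c4ccco4)c3n2)cc1` has not yet been measured. It differs from compound 3 in one place: methoxy in place of hydrogen on an aromatic carbon. Cut one bond further out, the same difference reads phenyl to 4-methoxyphenyl.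

Within the data shown here, only one step between measured compounds is known, a number 3 percentage points higher from compound 1 to compound 2 (within the scatter), and it concerns a benzyl in place of phenyl on an amide-type nitrogen, not the ring carrying the methoxy group. It therefore does not bear on the change in hand. Among the measured compounds shown here, compounds 1 and 2 do carry the methoxy group, but they also have a different amide part, so no pair isolates methoxy against hydrogen. For the measured compounds named here, with no step that speaks to this change, no shift beyond the scatter in this assay is expected for compound 4, and the estimated step of a number 2 percentage points lower from compound 3 to compound 4 (within the scatter) is small. The value of compound 4 is estimated at 18%, with a range from 5% to 35%.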

Compound 4, a percentage reported as inhibition, at one concentration (the size of the read-out at that concentration, not a potency): 6%
For compound 4 the middle estimate is 12 percentage points above the measured one; the range from low to high includes it.
By their numbers in this assay, from the lowest: compounds 1, 4 and 2 (each within the scatter of the next); then compound 3.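

In this assay, among these compounds, the change from phenyl to 4-methoxyphenyl on the furan amide gives a number 14 percentage points lower from compound 3 to compound 4 (beyond the scatter) and is the first pair here in which methoxy in place of hydrogen stands alone, so this aromatic carbon, para to a large group, is a place where the change alters the read-out. Among the compounds that carry the methoxy group, the amide part makes no difference beyond the scatter: furan-2-yl in place of benzylamino gives a number 2 percentage points lower from compound 2 to compound 4 (within the scatter) and furan-2-yl in place of anilino gives a number 1 percentage points higher from compound 1 to compound 4 (within the scatter) as the other comparison. Nothing in the available data gives a reason for the effect of the methoxy group.

Going by these compounds, it remains open whether a hydroxyl, an amine or a longer chain such as ethoxy at the same place would give a number near that of compound 3 or near that of compound 4. Also open, on these data alone, is whether hydrogen in place of methoxy would raise the number on the urea compounds, compound 1 and compound 2, as it does on the furan amide.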